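This account rests on a few compounds, and the source may have more. Where it says the series, first, only, none or still open, it means among the compounds named here.

The measured compounds and their numbers in a functional assay on RXF 393 cells (Homo sapiens) for inhibition, read by sulforhodamine B assay, with a stated time of 48 h; on this read-out higher numbers stand for weaker inhibition of growth and lower numbers for stronger inhibition of growth:

compound 1 `Nc1cc(N)c2nc(-c3ccccc3)c(NCc3ccc(Cl)c(Cl)c3)nc2c1` gives 17000 nM
compound 2 `Nc1cc(N)c2nc(-c3ccccc3)c(NCc3ccc(F)cc3)nc2c1` gives 26900 nM
compound 3 `COc1ccc(CNc2nc3cc(N)cc(N)c3nc2-c2ccccc2)cc1` gives 18200 nM

Among the measured compounds shown here, compound 2 has the highest of the three numbers, but its neighbours sit close: a 1.5-fold lower number from compound 2 to compound 3 (0.17 log units; within the scatter) and, seen from the other side, a 1.6-fold higher number from compound 1 to compound 2 (0.20 log units; within the scatter) are both within the usual scatter, so no compound here can be called stronger or weaker than another. The third measured step, a 1.1-fold higher number from compound 1 to compound 3 (0.03 log units; within the scatter), is within the scatter as well.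

Compound 4 `Nc1cc(N)c2nc(-c3ccccc3)c(Oc3ccc(F)cc3)nc2c1` differs from compound 2 in one place: 4-fluorophenoxy in place of (4-fluorobenzyl)amino on an aromatic carbon. All three measured steps swap one substituted benzyl ring for another; none exchanges the link that joins that ring to the shared core, and none removes the hydrogen-bond donor that the (4-fluorobenzyl)amino group carries. For the measured compounds named here, no measured step bears directly on this change. Since the three measured compounds fall within a narrow band despite different rings, the expectation for compound 4 is a number near that band, with a wide range to cover the untested change. Compound 4 is estimated at 30000 nM in this assay, with a range of 10000 nM to 90000 nM. The expected step, a 1.1-fold higher number from compound 2 to compound 4 (0.05 log units; within the scatter), is not beyond the scatter.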

Compound 4, concentration for total growth inhibition: < 100000 nM
Compound 4 ended at the assay's limit; the forecaster's own chance of this, stated with the estimate: 15%; the middle value does not contradict the limit.
By their numbers in this assay, from the lowest: compounds 1, 3 and 2 (each within the scatter of the next).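

In this assay compound 4 gives < 100000 nM, which is a limit of the assay and not a number. The step from compound 2 to compound 4 therefore cannot be read. The compounds shown leave open whether 4-fluorophenoxy in place of (4-fluorobenzyl)amino changes growth inhibition at all, and in which direction.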